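The source may hold more compounds than are shown below. What is called first, only, known or untested is meant among the compounds shown, and "the series" means these compounds.

Of the compounds shown here, three have so far been tested in a functional assay on SMMC-7721 cells (Homo sapiens) for inhibition, read by MTT assay, with a stated time of 72 h, tested at 10 uM; a lower number here means a weaker effect, a higher number a stronger effect of the compound at the concentration tested. Compound 1 `Clc1ccc2c(O/N=C(/C=C/c3ccc(OCc4ccccc4Cl)cc3)\C=C\c3ccccn3)ncnc2c1` gives 84.7% in this assay, which is the lowest of the three numbers. Compound 3 `Cc1cccc2ncnc(O/N=C(\C=C\c3ccccn3)/C=C/c3ccccc3OCc3ccccc3Cl)c12` gives 95.7% in this assay, a value that lies beyond the scatter above that of compound 1. Compound 2 `Cc1cccc(COc2ccc(/C=C/C(/C=C/c3ccccn3)=N/Oc3ncnc4ccccc34)cc2)c1` gives 97.5% in this assay, also beyond the scatter above compound 1 and the furthest of the three from it.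

Compound 4 `Fc1ccccc1COc1ccc(/C=C/C(/C=C/c2ccccn2)=N/Oc2ncnc3cc(Cl)ccc23)cc1` has not yet been measured. It differs from compound 1 in one place only: fluoro in place of chloro on an aromatic carbon. Everything else in the molecule stays as it is in compound 1. Going by the values given here, no pair of measured compounds shows this kind of exchange, so there is no measured step to go by. One halogen standing in for another at the same spot is expected to shift the read-out only a little, so the step of a number 0.7 percentage points lower from compound 1 to compound 4 (within the scatter) is expected to stay within the scatter and could go either way. Compound 4 is therefore estimated at 84% in this assay, with a range from 68% to 95%.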

Compound 4, a percentage reported as inhibition, at one concentration (the size of the read-out at that concentration, not a potency): 91.2%
For compound 4 the middle estimate is 7.2 percentage points below the measured one; the measured number falls inside the stated range.
By their numbers in this assay, from the lowest: compounds 1, 4, 3 and 2 (each within the scatter of the next, the first and the last beyond it).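

Going by these compounds alone, exchanging chloro for fluoro on an aromatic carbon, ortho to a large group, gives a first measured step at this position: a number 6.5 percentage points higher from compound 1 to compound 4 (within the scatter) in this assay. For this one pair, the 2-chlorobenzyl and 2-fluorobenzyl versions therefore cannot be told apart, and the change of halogen leaves the read-out within its usual spread. Nothing available explains this result or links it to any property of either halogen.

Going by these compounds, whether this position would accept a group of a different kind, such as an amine or a carboxylic acid, remains open, since only these two halogens can be compared here. The read-out also comes from a single concentration, so compounds that look alike here could still give a stronger or weaker effect at other concentrations.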